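A propylamino analogue in the uracil series: expected lipophilicity

The compounds below may be only part of what the source reports. "The series", "measured", "known", "first", "only" and "open" are said of these compounds alone.

Measured compounds:
Compound 1, `CCN(CC)c1c(C)n(-c2ccccc2)c(=O)n(C)c1=O`: 2.19
Compound 2, `Nc1nc(N)nc(-c2cc(Br)ccc2Cl)n1`: 2.04
Compound 3, `C=CCN(CC=C)c1c(C)n(-c2ccccc2)c(=O)n(C)c1=O`: 2.59

Of the compounds shown here, three have been measured in a physicochemical assay for lipophilicity; on this read-out higher numbers stand for higher lipophilicity and lower numbers for lower lipophilicity. Compound 1, with a diethylamino group on the shared core, gives 2.19. Compound 2 belongs to a different core and gives 2.04. Compound 3 gives 2.59 and stands highest of the three numbers; its nearest neighbour is compound 1, and compound 2 lies furthest away, both of those gaps being beyond the scatter.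

Compound 4, `CCCNc1c(C)n(-c2ccccc2)c(=O)n(C)c1=O`, has not been measured. It differs from compound 3 in one place: propylamino in place of diallylamino on an aromatic carbon.

Going by the values given here, only one measured step bears on this change: a number 0.40 log units higher from compound 1 to compound 3 (beyond the scatter). That step shows how the replacement of two small alkyl chains by two unsaturated ones shifted this assay upward by a modest amount. The change to compound 4 goes the other way and further: the propylamino group carries fewer heavy atoms than either the diallylamino group of compound 3 or the diethylamino group of compound 1, and it brings in a hydrogen-bond donor. A downward step beyond the scatter is therefore expected, somewhat larger than the measured step, placing compound 4 under compound 1.

Compound 4 is estimated at 1.85, with a likely range from 1.45 to 2.25, which corresponds to an expected step of a number 0.74 log units lower from compound 3 to compound 4 (beyond the scatter).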

Compound 4, partition coefficient: 1.7
Estimate against measurement, compound 4: 0.15 log units above; the measured number falls inside the stated range.
By their numbers in this assay, from the lowest: compound 4; then compounds 2 and 1 (each within the scatter of the next); then compound 3.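

In this assay, going by these compounds alone, the earlier compounds showed this position on an aromatic carbon of the shared core only with diethylamino and diallylamino, and the step between those two went upward; propylamino now extends the range downward at the same position, with a number 0.89 log units lower from compound 3 to compound 4 (beyond the scatter). The fall also holds against the saturated diethylamino group, with a number 0.49 log units lower from compound 1 to compound 4 (beyond the scatter), so it does not depend on losing the 2 double bonds of diallylamino, and all three groups stand apart beyond the scatter at this position. Nothing shown gives a measured reason for either step.

The change from diallylamino to propylamino removes heavy atoms and brings in 1 hydrogen-bond donor in a single move, so these compounds cannot tell how much of the fall belongs to the smaller group and how much to the donor. Dipropylamino on the same core would keep the propyl chain without that donor, while butylamino would keep the donor on a longer chain, and neither group is among the compounds shown here.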